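The compounds below may be only part of what the source reports. "The series", "measured", "known", "first", "only" and "open" are said of these compounds alone.

Measured compounds in an assay on CHO cells for displacement of a labelled ligand from adenosine receptor A3 (Homo sapiens), read by scintillation counting, with a stated time of 45 min, tested at 1 uM, in the presence of a further agent that is not named here; on this read-out lower numbers stand for less inhibition and higher numbers for more inhibition at the one concentration tested (going by the name of the read-out):
compound 1 `CCCn1c(=O)[nH]c2nc(-c3ccc(S(=O)(=O)N4CCN(c5ccc(Cl)cc5F)CC4)cc3)[nH]c2c1=O` gives 14%
compound 2 `CCCn1c(=O)[nH]c2nc(-c3ccc(S(=O)(=O)N4CCN(C)CC4)cc3)[nH]c2c1=O` gives 7%
compound 3 `CCCn1c(=O)[nH]c2nc(-c3ccc(S(=O)(=O)N4CCN(Cc5cccc(Br)c5)CC4)cc3)[nH]c2c1=O` gives 23%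

Compound 1 stands second highest of the three numbers. Its nearest neighbour is compound 2, a step of a number 7 percentage points lower from compound 1 to compound 2 (within the scatter), and the furthest is compound 3, a step of a number 9 percentage points higher from compound 1 to compound 3 (within the scatter); both lie within the scatter, so no order among the three is settled by them. Among the measured compounds shown here, the only step beyond the scatter in the set is a number 16 percentage points higher from compound 2 to compound 3 (beyond the scatter).

Compound 4 `CCCn1c(=O)[nH]c2nc(-c3ccc(S(=O)(=O)N4CCN(c5cccc(Br)c5)CC4)cc3)[nH]c2c1=O` differs from compound 1 in one place: 3-bromophenyl in place of 4-chloro-2-fluorophenyl on an amine nitrogen in a ring. For the measured compounds named here, the steps that bear on it are those that alter the group on the same ring nitrogen. Exchanging the 4-chloro-2-fluorophenyl for methyl gave a number 7 percentage points lower from compound 1 to compound 2 (within the scatter), and for 3-bromobenzyl gave a number 9 percentage points higher from compound 1 to compound 3 (within the scatter); neither left the scatter. Going by the values given here, compound 4 carries the 3-bromophenyl directly on the amine nitrogen and lacks the saturated chain carbon that compound 3 has, so there is no exact precedent, but compounds 1 and 3 sit close together and compound 2 is not far off. The expectation for compound 4 is therefore a step of a number 4 percentage points higher from compound 1 to compound 4 (within the scatter), not beyond the scatter. Compound 4 is estimated at 18%, with a range of 5% to 32%.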

Compound 4, a percentage reported as inhibition, at one concentration (the size of the read-out at that concentration, not a potency): 27%
Estimate against measurement, compound 4: 9 percentage points below, and the stated range covers the measured number.
By their numbers in this assay, from the lowest: compounds 2, 1, 3 and 4 (each within the scatter of the next, the first and the last beyond it).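

In this assay, exchanging one halogen-bearing phenyl for another on the amine nitrogen in the ring gives a number 13 percentage points higher from compound 1 to compound 4 (beyond the scatter), the first step from compound 1 to leave the scatter, although the groups that leave and enter have the same ring and the same zero counts of hydrogen-bond donors and acceptors. Both bromine-bearing groups now stand clear of methyl, with a number 20 percentage points higher from compound 2 to compound 4 (beyond the scatter) alongside a number 16 percentage points higher from compound 2 to compound 3 (beyond the scatter), whereas the 4-chloro-2-fluorophenyl of compound 1 does not, and a number 4 percentage points higher from compound 3 to compound 4 (within the scatter) shows no readable effect of the saturated chain carbon in this pair. No measurement at hand accounts for these steps.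

From the compounds shown here alone, the change removes chlorine and fluorine and brings in bromine in one move, so the contribution of each halogen and of its ring position stays open, and an unsubstituted phenyl or a 3-chlorophenyl on the same nitrogen would separate them. Also open, going by these compounds, is how a group of another kind on this nitrogen, such as a carboxylic acid, an amine or a longer chain, would read in this assay, and what these single-concentration numbers mean for potency.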